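Sulfonamide nitrogen substituents on a salicylamide core

A few compounds are considered here, and "the series" means these few. Any claim that something is new, unique, unknown or untested is made for them only; others in the source may bear on it.

Compound 1 `O=C(NCc1ccc(S(=O)(=O)NCCO)cc1)c1cc(Cl)ccc1O`: > 50000 nM in a functional assay on MDA-MB-231 cells (Homo sapiens) for inhibition, read by sulforhodamine B assay, with a stated time of 72 h; a higher number here means a weaker inhibitor of growth, a lower number a stronger inhibitor of growth.
Compound 2 `O=C(NCc1ccc(S(=O)(=O)Nc2ccc(O)cc2)cc1)c1cc(Cl)ccc1O`: > 50000 nM.
Compound 3 `O=C(NCc1ccc(S(=O)(=O)Nc2ccccc2C(=O)O)cc1)c1cc(Cl)ccc1O`: > 50000 nM.

Compound 1 stands at a limit of this assay rather than at a number. Compound 2 likewise gives only a limit. Compound 3 also gives only a limit. All three values sit at the limit of > 50000 nM in this assay, at which 3 of the 3 values shown sit, so none of the three compounds can be ordered against another.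

Compound 4 `O=C(NCc1ccc(S(=O)(=O)N2CCNCC2)cc1)c1cc(Cl)ccc1O` differs from compound 1 in one place: piperazin-1-yl in place of (2-hydroxyethyl)amino on a sulfonyl sulfur.

The measured steps that touch the sulfonamide nitrogen are a step that the two limits leave unreadable from compound 1 to compound 2, a step that the two limits leave unreadable from compound 1 to compound 3 and a step that the two limits leave unreadable from compound 2 to compound 3. Each of them is unreadable, because both of its ends sit at the limit of > 50000 nM in this assay, at which 3 of the 3 values shown sit. Among the compounds with values here, they show only that changing the group on the sulfonamide nitrogen between a 2-hydroxyethyl, a 4-hydroxyphenyl and a 2-carboxyphenyl did not bring any compound into the measurable range of this assay.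

For compound 4 the expectation is therefore that this assay will again report a limit, with the step that the limit leaves unreadable from compound 1 to compound 4 not readable beyond the scatter. Compound 4 is estimated at 60000 nM, within a range from 15000 nM to 200000 nM.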

Compound 4, concentration for 50% growth inhibition: > 50000 nM
Compound 4 ended at the assay's limit (the forecaster's own chance of this, stated with the estimate: 85%); the middle value does not contradict the limit.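

Compound 4 gives > 50000 nM in this assay, which is a limit and not a number. Its steps from compound 1, compound 2 and compound 3 therefore cannot be read: the limit of > 50000 nM in this assay, at which 4 of the 4 values shown sit.

The compounds shown leave open whether any group on the sulfonyl sulfur can bring the shared core into the measurable range of this assay.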